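The source may report more compounds than this note shows. Statements on the series, on what has been measured and on what is new or still open speak of the compounds shown alone.

Working notes on the series, following the step from compound 3 `N=c1sc2cc(OC(F)(F)F)ccc2n1CC(=O)O` to compound 4 `CS(=O)(=O)CCCn1c(=N)sc2cc(OC(F)(F)F)ccc21`. In a functional assay on the whole organism with Rattus norvegicus as the target (a lower number here means that less compound is needed, a higher number that more compound is needed for the effect), compound 3 reaches only the bound of > 10 mg/kg, a limit of the assay and not a number. The change is 2-(methylsulfonyl)ethyl in place of carboxy on a saturated chain carbon bound to an aromatic nitrogen. Compound 1 `C[Si](C)(C)c1ccc2nc(N)sc2c1` gives 5 mg/kg in this assay. Compound 2 `CC(C)c1ccc2nc(N)sc2c1` sits at > 10 mg/kg in this assay, again a limit and not a number. Going by the values given here, the single measured step, an at least 2.0-fold higher number from compound 1 to compound 2 (0.30 log units; that floor lies within the scatter), concerns a different position on the core and does not bear on the carboxy to 2-(methylsulfonyl)ethyl exchange; no measured step informs it. Given (the limit of > 10 mg/kg in this assay, at which 2 of the 3 values shown sit), no step beyond the scatter is expected in this assay, and a reading near the bound is anticipated. Compound 4 is estimated at 15 mg/kg, within 4 mg/kg to 60 mg/kg. That estimate means an expected step that the limit leaves unreadable from compound 3 to compound 4.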

Compound 4, dose for half-maximal effect: 5 mg/kg
Beside the measured number, compound 4's estimate is 3.0-fold (0.48 log units) above it, and the stated range covers the measured number.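

In this assay, 2-(methylsulfonyl)ethyl in place of carboxy on a saturated chain carbon bound to an aromatic nitrogen gives an at least 2.0-fold lower number from compound 3 to compound 4 (0.30 log units; that floor lies within the scatter). Among the compounds shown, compound 4 holds the only number with a group at this place. Compound 3 stands at a limit and not a number, so the true size of the step cannot be read: the limit of > 10 mg/kg in this assay, at which 2 of the 4 values shown sit.

Going by these compounds, it remains open whether the sulfonyl group or the longer chain accounts for the step. A plain propyl chain or a sulfonamide at this place would separate the two.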